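A few compounds are considered here, and "the series" means these few. Any claim that something is new, unique, unknown or untested is made for them only; others in the source may bear on it.

Measured compounds:
- compound 1 `COc1cc(N/C=C\C(=O)c2cn(-c3ccccc3)nc2-c2ccc(F)cc2)cc(OC)c1OC` gives 4890 nM
- compound 2 `COc1cc(-c2nn(-c3ccccc3)cc2C(=O)/C=C\Nc2ccc(Cl)cc2)cc(OC)c1OC` gives 11200 nM

These two compounds were tested in a functional assay on PC-3 cells (Homo sapiens) for antiproliferative activity, read by MTT assay, with a stated time of 48 h; a lower number here means a stronger inhibitor, a higher number a weaker inhibitor. Compound 1 gives the lower of the two numbers, and compound 2 stands highest of the two: the gap between compound 1 and compound 2 is beyond the usual scatter of repeated measurements, so compound 2 is the weaker inhibitor here. The two compounds differ in more than one place, so the gap cannot be tied to a single structural feature.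

Compound 3 `COc1cc(N/C=C\C(=O)c2cn(-c3ccccc3)nc2-c2cc(OC)c(OC)c(OC)c2)cc(OC)c1OC` has not yet been measured. It differs from compound 2 in one place: 3,4,5-trimethoxyphenyl in place of 4-chlorophenyl on an amine nitrogen. The same 3,4,5-trimethoxyphenyl group on the amine nitrogen is present in compound 1, and compound 1 gives the lower number in this assay; compound 3 carries this group together with the other features of compound 2. On that basis compound 3 is expected to give a somewhat lower number than compound 2, a step of a 3.2-fold lower number from compound 2 to compound 3 (0.51 log units; beyond the scatter), though a change no larger than the scatter would not be surprising. The estimate for compound 3 in this assay is 3500 nM, within a range from 900 nM to 14000 nM.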

Compound 3, half-maximal inhibitory concentration: 14100 nM
Beside the measured number, compound 3's estimate is 4.0-fold (0.61 log units) below it; the whole stated range lies below it.
By their numbers in this assay, from the lowest: compound 1; then compounds 2 and 3 (each within the scatter of the next).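

In this assay, a 1.3-fold higher number from compound 2 to compound 3 (0.10 log units; within the scatter) shows that, with 3,4,5-trimethoxyphenyl already on the aromatic carbon, the 4-chlorophenyl and 3,4,5-trimethoxyphenyl groups on the amine nitrogen cannot be told apart, even though they differ in size and in their hydrogen-bond acceptors. The second comparison keeps 3,4,5-trimethoxyphenyl on the amine nitrogen and changes only the aromatic carbon, where 3,4,5-trimethoxyphenyl in place of 4-fluorophenyl gives a 2.9-fold higher number from compound 1 to compound 3 (0.46 log units; beyond the scatter), a modest step beyond the scatter, so this group on the nitrogen does not by itself bring the lower number of compound 1, and the aromatic carbon is the one place here where a single change gives a readable step. No measurement shown explains either result.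

Two aryl groups on the amine nitrogen cannot show whether that position tolerates change in general, so a simple methyl group or a phenyl ring carrying a carboxylic acid could behave differently there. From the compounds shown here alone, it also remains open whether the nitrogen groups would stay indistinguishable with 4-fluorophenyl on the aromatic carbon, or whether an unsubstituted phenyl on that carbon would give a number nearer to that of compound 1 or to that of compound 3.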